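Extending a histamine antagonist pair by a phenylsulfanylmethyl group

A few compounds are considered here, and "the series" means these few. Any claim that something is new, unique, unknown or untested is made for them only; others in the source may bear on it.

Compound 3 `CN/C(=N/C#N)NCCCCc1nc[nH]c1C` is the measured parent of the pair followed here. In a functional assay on Sf9 cells for antagonist activity at histamine H2 receptor (Homo sapiens), read by scintillation counting and GTPgammaS binding, with a stated time of 90 min (a higher number here means a more potent compound, by a factor of ten per unit of this negative logarithm, a lower number a less potent compound), compound 3 gives only a limit, < 5, and not a number. Two related compounds stand at the same place. Compound 1 `CN/C(=N/C#N)NCCCc1c[nH]c(C)n1` gives in this assay a limit, < 5. Compound 2 `Cc1nc(CCCN/C(=N\C#N)NCCSc2ccccc2)c[nH]1` likewise gives in this assay a limit, < 5. Because (the limit of < 5 in this assay, at which 3 of the 3 values shown sit), no order among the three can be read. Compound 4 `Cc1[nH]cnc1CCCCN/C(=N\C#N)NCCSc1ccccc1` differs from compound 3 by (phenylsulfanyl)methyl in place of hydrogen on a saturated chain carbon bound to an amine nitrogen. The same change has been made once before within these compounds: a step that the two limits leave unreadable from compound 1 to compound 2. Both ends of that step are limits; its size is not known, and it gives no direction for the corresponding step in this assay. The estimate for compound 4 in this assay is 4.8, within 4 to 5.8, with a real chance that the assay again reports only a limit. The step that the limit leaves unreadable from compound 3 to compound 4 that this estimate implies is expected to be small.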

Compound 4, negative logarithm of the antagonist equilibrium constant: 5.36
Estimate against measurement, compound 4: 0.56 log units below; the range from low to high includes it.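

In this assay, the (phenylsulfanyl)methyl change on a saturated chain carbon bound to an amine nitrogen now has a readable direction, which the step from compound 1 to compound 2 could not give, as that step cannot be read: a number at least 0.36 log units higher from compound 3 to compound 4 (beyond the scatter). The change of (5-methyl-1H-imidazol-4-yl)methyl in place of 2-methyl-1H-imidazol-4-yl also counts with the (phenylsulfanyl)methyl group present: a number at least 0.36 log units higher from compound 2 to compound 4 (beyond the scatter). Compound 4 is the only one of the four compounds with a number, so both steps give only a smallest size: the limit of < 5 in this assay, at which 3 of the 4 values shown sit.

On these data alone, the true size of either step remains open, as does the size of the same change in the pair of compound 1 and compound 2. As far as these compounds go, whether a longer chain or an amine in place of the (phenylsulfanyl)methyl group would keep this potency is also open.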